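This account rests on a few compounds, and the source may have more. Where it says the series, first, only, none or still open, it means among the compounds named here.

The measured compounds are compound 1 `Cc1cccc(-n2cc(-c3ccccc3NS(=O)(=O)c3c[nH]c(=O)[nH]c3=O)nn2)c1` with 3150 nM, compound 2 `Cc1ccc(-n2cc(-c3ccccc3NS(=O)(=O)c3c[nH]c(=O)[nH]c3=O)nn2)cc1` with 2190 nM, and compound 3 `Cc1cccc(-n2cc(-c3ccc(NS(=O)(=O)c4c[nH]c(=O)[nH]c4=O)cc3)nn2)c1` with 7490 nM, all in a functional assay on OVCAR-3 cells (Homo sapiens) for antiproliferative activity, read by MTT assay, with a stated time of 24 h; on this read-out lower numbers stand for stronger inhibition and higher numbers for weaker inhibition.

Compound 1 and compound 2 share one core; compound 3 is built on a different core, and the difference between the two cores is not broken down here. Within the first pair, compound 2 carries 4-methylphenyl in place of 3-methylphenyl on an aromatic nitrogen, and this change gave a 1.4-fold lower number from compound 1 to compound 2 (0.16 log units; within the scatter), so the two values are treated as equivalent. Compound 3 gives the highest of the three numbers, and its gaps to compound 1 and to compound 2 both lie beyond the scatter.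

Compound 4 `Cc1ccc(-n2cc(-c3ccc(NS(=O)(=O)c4c[nH]c(=O)[nH]c4=O)cc3)nn2)cc1` is not yet measured. It stands to compound 3 as compound 2 stands to compound 1: it carries 4-methylphenyl in place of 3-methylphenyl on an aromatic nitrogen, the same change at the same place. Because the earlier step of a 1.4-fold lower number from compound 1 to compound 2 (0.16 log units; within the scatter) stayed within the scatter, the step from compound 3 to compound 4 is expected to be small as well, estimated at a 1.4-fold lower number from compound 3 to compound 4 (0.13 log units; within the scatter). Compound 4 is therefore expected to give about 5500 nM in this assay, most likely between 2800 nM and 11000 nM.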

Compound 4, half-maximal inhibitory concentration: 5630 nM
The estimate for compound 4 lay 1.0-fold (0.01 log units) below the measured number, within the range that was stated.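

In this assay, 4-methylphenyl in place of 3-methylphenyl on the aromatic nitrogen gave a 1.3-fold lower number from compound 3 to compound 4 (0.12 log units; within the scatter), so compound 3 and compound 4 are treated as equivalent. The change behaved alike on the two cores: the same change on two cores in this assay, a 1.4-fold lower number (0.16 log units; within the scatter) from compound 1 to compound 2 and a 1.3-fold lower number (0.12 log units; within the scatter) from compound 3 to compound 4, 1.1-fold (0.03 log units) apart, within the scatter of two such steps. Within this series, then, a swap that left the number within the scatter on the core of compound 1 did the same on the core of compound 3, but this rests on two pairs in a single assay and does not show that either methylphenyl is better than the other, nor that a change with a larger effect would carry over as faithfully.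

The compounds shown leave open what other groups on the aromatic nitrogen, such as a carboxylic acid, an amine or a longer alkyl chain in place of the methylphenyl, would do on either core. They also leave open whether such groups would carry from one core to the other as this swap did.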